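A few compounds are considered here, and "the series" means these few. Any claim that something is new, unique, unknown or untested is made for them only; others in the source may bear on it.

Compound 1 `COc1cc(/C=C/C(=O)/C=C(/C=C/c2ccc(O)c(OC)c2)NCCO)ccc1O`: 87200 nM
Compound 2 `COc1cc(/C=C/C2=CC(=O)CC(c3ccc(O)c(OC)c3)N2CCCO)ccc1O`: 88000 nM
Compound 3 `COCCCN1C(/C=C/c2ccc(O)cc2)=CC(=O)CC1c1ccc(O)cc1`: > 100000 nM

In a functional assay on Caco-2 cells (Homo sapiens) for cytotoxicity, read by MTT assay, with a stated time of 48 h (a lower number here means a stronger inhibitor, a higher number a weaker inhibitor), compound 1 gives 87200 nM, and compound 2 gives 88000 nM, which lies within the scatter of compound 1. Compound 3 reads > 100000 nM, and this is a limit of the assay, not a number. Compound 4 `COCCNC(=C\C(=O)/C=C/c1ccc(O)c(OC)c1)/C=C/c1ccc(O)c(OC)c1` has not yet been measured. It differs from compound 1 by methyl in place of hydrogen on an oxygen on a saturated carbon, with 2-hydroxyethyl changed to 2-methoxyethyl. Going by the values given here, no measured pair shows this change, so no step beyond the scatter is expected in this assay. The estimated 1.0-fold lower number from compound 1 to compound 4 (0.01 log units; within the scatter) is small and has no firm direction. For compound 4 the expected value is 85000 nM, with an estimated range from 40000 nM to 100000 nM.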

Compound 4, half-maximal inhibitory concentration in the Caco-2 assay: > 100000 nM
Compound 4: no number, only a limit (the forecaster's own chance of this, stated with the estimate: 25%); middle value at least 1.1-fold (0.07 log units) from the limit.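

Going by these compounds alone, compound 1 and compound 4 form the one pair that isolates 2-hydroxyethyl to 2-methoxyethyl, and in the Caco-2 assay this change reads an at least 1.1-fold higher number from compound 1 to compound 4 (0.05 log units; that floor lies within the scatter). In the Caco-2 assay compound 4 reads > 100000 nM, and this is a limit of the assay, not a number. So the step has a floor and no measured size, and the reading sits at the edge of the assay: the limit of > 100000 nM in the Caco-2 assay, at which 2 of the 4 values shown sit.

In a physicochemical assay for solubility, using the shake flask method, in phosphate buffer, with a stated time of 24 h, at pH 6.8 (on this read-out higher numbers stand for higher solubility and lower numbers for lower solubility), where both compounds carry numbers, compound 1 gives 11800 nM and compound 4 gives 12700 nM, and the same change reads a 1.1-fold higher number from compound 1 to compound 4 (0.03 log units; within the scatter).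

The compounds shown leave open how an ethyl ether, a longer chain, an amine or a carboxylic acid at this position would read in either assay.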